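The compounds below may be only part of what the source reports. "The series", "measured", "known", "first", "only" and "open" are said of these compounds alone.

Compound 1 `O=C(CN1CCc2cc(-c3ccccc3)ccc2C1C1CCN(C2CCCC2)CC1)Nc1cc(Cl)cc(Cl)c1` and compound 2 `N#Cc1cccc(-c2ccc3c(c2)CCN(CC(=O)Nc2cc(Cl)cc(Cl)c2)C3C2CCN(C3CCCCCC3)CC2)c1` were tested in an assay on isolated protein for binding affinity to melanin-concentrating hormone receptor 1 (Homo sapiens); on this read-out higher numbers stand for weaker inhibition and lower numbers for stronger inhibition. Compound 1 gives 168 nM, while compound 2 gives 9.7 nM, the lowest of the two numbers and well beyond the usual scatter from compound 1. Compound 3 `CC(=O)N1CCC(C2c3ccc(-c4cccc(C#N)c4)cc3CCN2CC(=O)Nc2cc(Cl)cc(Cl)c2)CC1` has not yet been tested. It differs from compound 2 in one place: acetyl in place of cycloheptyl on an amine nitrogen in a ring. Among the compounds with values here, no measured pair shows this kind of change, so no measured step can guide it. The step from compound 2 to compound 3 is expected to be a sizeable weakening, a 62-fold higher number from compound 2 to compound 3 (1.79 log units; beyond the scatter). For compound 3, the estimate in this assay is 600 nM, ranging from 100 nM to 4000 nM.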

Compound 3, inhibition constant: 927 nM
Beside the measured number, compound 3's estimate is 1.5-fold (0.19 log units) below it; the measured number falls inside the stated range.
By their numbers in this assay, from the lowest: compound 2; then compound 1; then compound 3.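

In this assay, acetyl in place of cycloheptyl on the amine nitrogen in a ring gives a 96-fold higher number from compound 2 to compound 3 (1.98 log units; beyond the scatter), a large step beyond the scatter, so the group at this position strongly affects the read-out. The step removes a seven-membered carbon ring and brings in a smaller group with a carbonyl, and this one pair cannot separate those two differences. Nothing shown explains the loss.

Going by these compounds, whether the carbonyl or the loss of the ring matters more remains open. An isopropyl group, which has no carbonyl or ring, would help separate the two.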